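Bromine on Two Fused Cores and Cell Tolerance

The source may report more compounds than this note shows. Statements on the series, on what has been measured and on what is new or still open speak of the compounds shown alone.

Three compounds built on the same two-ring core carrying a side chain have been tested in an ADME assay on HEK-293T cells (Homo sapiens) for cytotoxicity, read by luminescence and CellTiter-Glo, with a stated time of 24 h; a higher number here means that more compound is tolerated, a lower number that less compound is tolerated. Compound 1 `CCCNC(=O)C1CCN(C(=O)c2cc3ccsc3n2Cc2ccc(OC)cc2)CC1` gives 23400 nM. Compound 3 `CCCNC(=O)C1CCN(C(=O)c2cc3ccccc3n2Cc2ccc(OC)cc2)CC1` gives 26000 nM, and this number and that of compound 1 sit within the usual scatter of each other, so neither can be ranked above the other. How the core of compound 1 differs from the core of compound 3 is not broken down here.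

For compound 2 `CCCNC(=O)C1CCN(C(=O)c2cc3cc(Br)ccc3n2Cc2ccc(OC)cc2)CC1` the result is a limit of the assay rather than a number: > 100000 nM. This rests on (the limit of > 100000 nM in this assay, at which 1 of the 3 values shown sits). The change from compound 3 to compound 2 is bromo in place of hydrogen on an aromatic carbon, and it produced an at least 3.8-fold higher number from compound 3 to compound 2 (0.58 log units; beyond the scatter).

Compound 4 `CCCNC(=O)C1CCN(C(=O)c2cc3cc(Br)sc3n2Cc2ccc(OC)cc2)CC1` has not yet been tested. Among the measured compounds shown here, it comes from compound 1 by bromo in place of hydrogen on an aromatic carbon, the same kind of change as the one from compound 3 to compound 2, though not the same: there the place was a six-membered aromatic ring of carbon only, meta to a fused ring and para to a fused ring, whereas here it is a five-membered aromatic ring with 1 sulfur, next to the ring sulfur. Given the step seen in an at least 3.8-fold higher number from compound 3 to compound 2 (0.58 log units; beyond the scatter), the expected step is a 2.6-fold higher number from compound 1 to compound 4 (0.41 log units; beyond the scatter), leaning toward a higher number for compound 4. The estimate for compound 4 in this assay is 60000 nM, expected to fall between 25000 nM and 150000 nM.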

Compound 4, half-maximal cytotoxic concentration: > 100000 nM
Compound 4 was reported as a limit; the forecaster's own chance of this, stated with the estimate: 40%; at least 1.6-fold (0.22 log units) between middle value and limit.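

In this assay, bromo in place of hydrogen on an aromatic carbon also gives a higher number on the core of compound 1, with an at least 4.2-fold higher number from compound 1 to compound 4 (0.63 log units; beyond the scatter), so more compound is tolerated after the change on this core too. Set side by side, the two pairs move in the same direction, which shows that the change carries from one core to the other in direction, although this rests on only these two pairs: the same change on two cores in this assay, an at least 3.8-fold higher number (0.58 log units; beyond the scatter) from compound 3 to compound 2 and an at least 4.2-fold higher number (0.63 log units; beyond the scatter) from compound 1 to compound 4; the limit leaves it open whether they differ

What this does not show is the true size of either step, or whether one core responds more strongly than the other, since both compounds with bromo give only a limit of the assay and not a number: the limit of > 100000 nM in this assay, at which 2 of the 4 values shown sit.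

The compounds shown leave open whether a different group on the same aromatic carbon, such as chloro, methyl or an amine, would move the number in the same way as bromo. They also leave open whether bromo would give a higher number on other aromatic carbons of these two cores, or on a third core, and how far the tolerated concentration truly lies past the limit.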